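Extending the Saturated Chain of Compound 2

This account rests on a few compounds, and the source may have more. Where it says the series, first, only, none or still open, it means among the compounds named here.

Compound 1 `CCCCCCCC(=O)NCC(C)(C)CC1=C(O)C(=O)c2ccccc2C1=O`: 24600 nM
Compound 2 `CCCCCCCCCC(=O)NCC(C)(C)CC1=C(O)C(=O)c2ccccc2C1=O`: 18500 nM
Compound 3 `CCCCCCCCCCCCCCCC(=O)NCC(C)(C)CC1=C(O)C(=O)c2ccccc2C1=O`: not yet measured

Among the compounds with values here, in a functional assay on KB cells (Homo sapiens) for cytotoxicity, read by resazurin assay, with a stated time of 3 days (on this read-out lower numbers stand for stronger inhibition and higher numbers for weaker inhibition), compound 2 gives 18500 nM, and it has only one measured neighbour. The record shows a 1.3-fold lower number from compound 1 to compound 2 (0.12 log units; within the scatter), so the two values cannot be told apart.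

Compound 3 keeps the shared core and changes only the saturated chain: hexyl in place of hydrogen on a saturated chain carbon, nine bonds along the chain from a carbonyl carbon. This is a larger addition to the same chain than the one already measured.

Within the data shown here, only one measured step bears on this change, and it is the step above, where ethyl replaced a hydrogen on the same chain. It stayed within the scatter, and a single step of that kind says little about how a much longer chain will behave. There is therefore only weak support for a slightly lower number, and no firm reason to expect a change beyond the scatter in this assay. The expected change is a 1.3-fold lower number from compound 2 to compound 3 (0.12 log units; within the scatter).

Compound 3 is estimated at 14000 nM, with an expected range of 4500 nM to 42000 nM.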

Compound 3, half-maximal inhibitory concentration: 5120 nM
Compound 3: middle estimate off by 2.7-fold (0.44 log units), on the high side; the range from low to high includes it.
By their numbers in this assay, from the lowest: compound 3; then compounds 2 and 1 (each within the scatter of the next).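

In this assay the chain now makes a measurable difference: hexyl in place of hydrogen on a saturated chain carbon, nine bonds along the chain from a carbonyl carbon, gives a 3.6-fold lower number from compound 2 to compound 3 (0.56 log units; beyond the scatter) and so clears the scatter, which the smaller ethyl addition did not do. Measured against the shortest chain shown, the long chain gives a 4.8-fold lower number from compound 1 to compound 3 (0.68 log units; beyond the scatter) as a step of similar modest size, so both routes to compound 3 agree that this long chain goes with a lower number than either shorter one. No measurement shown here accounts for this difference.

Within the data shown here, three compounds cannot show how the number depends on chain length, since the data hold only one clear step and do not reveal where between the shorter chains and compound 3 the change sets in. A still longer chain might lower the number further or might not, and a chain of the same length ending in an amine or a carboxylic acid would show whether the saturated carbon chain itself matters.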